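The source may report more compounds than this note shows. Statements on the series, on what has been measured and on what is new or still open speak of the compounds shown alone.

Measured so far: compound 1 `CC1CCN(c2cc(C(F)(F)F)ccc2CNC(=O)C(C)c2ccc(NS(C)(=O)=O)c(F)c2)CC1` gives 0.9 nM; compound 2 `CC(C(=O)NCc1ccc(C(F)(F)F)cc1OC1CCCC1)c1ccc(NS(C)(=O)=O)c(F)c1` gives 0.6 nM; compound 3 `CC(C(=O)NCc1ccc(C(F)(F)F)cc1SCCCO)c1ccc(NS(C)(=O)=O)c(F)c1` is recorded as "not active" (no number reported).

All three share the same core and differ only in the group carried on the aromatic carbon ortho to a large group and meta to a trifluoromethyl group. In an assay on CHO cells for antagonist activity at transient receptor potential cation channel subfamily V member 1 (Homo sapiens), read by FLIPR (a lower number here means a stronger inhibitor, a higher number a weaker inhibitor), compound 1 and compound 2 both give strong inhibition, and the change between them, a 1.5-fold lower number from compound 1 to compound 2 (0.18 log units; within the scatter), tells that 4-methylpiperidin-1-yl and cyclopentyloxy behave alike there. Going by the values given here, compound 3, carrying (3-hydroxypropyl)sulfanyl at that place, stands apart: in this assay it is reported as "not active" (no number reported) and no number is given, so no step from compound 3 to any other compound can be sized.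

Compound 4 `COc1cc(OC)cc(-c2cc(C(F)(F)F)ccc2CNC(=O)C(C)c2ccc(NS(C)(=O)=O)c(F)c2)c1` is not yet measured. The change from compound 3 is 3,5-dimethoxyphenyl in place of (3-hydroxypropyl)sulfanyl on an aromatic carbon. Among the compounds with values here, no measured step covers this exact exchange; the only step that bears on the same position, the one from compound 1 to compound 2, lies within the scatter, and it links two groups that both gave strong inhibition. With a ring-bearing group returned to that position, compound 4 is expected to regain measurable inhibition in this assay, estimated near 3 nM, between 0.5 nM and 30 nM.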

Compound 4, inhibition constant: 5.8 nM
Beside the measured number, compound 4's estimate is 1.9-fold (0.29 log units) below it; the range from low to high includes it.
By their numbers in this assay, from the lowest: compounds 2 and 1 (each within the scatter of the next); then compound 4.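

In this assay, 3,5-dimethoxyphenyl on an aromatic carbon ortho to a large group and meta to a trifluoromethyl group gives a measured number, whereas (3-hydroxypropyl)sulfanyl at that place in compound 3 gave none, so every step from compound 3 cannot be read. Going by these compounds alone, the earlier compounds showed only two groups at this position that could not be told apart, while the new result separates 3,5-dimethoxyphenyl from both, with a 9.7-fold higher number from compound 2 to compound 4 (0.99 log units; beyond the scatter) and a 6.4-fold higher number from compound 1 to compound 4 (0.81 log units; beyond the scatter), the first steps at this place beyond the scatter. Nothing available gives a reason for these steps or for the result with compound 3.

The compounds shown leave open whether the higher number of compound 4 goes with the aromatic ring itself or with its two methoxy groups, a question that an unsubstituted phenyl group at this place would address. They also leave open whether the result for compound 3 goes with the sulfur or with the hydroxyl, which a plain propylsulfanyl chain or a 3-hydroxypropoxy chain would separate.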